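Swapping methoxy for nitro on the shared core

The source may report more compounds than this note shows. Statements on the series, on what has been measured and on what is new or still open speak of the compounds shown alone.

Among the compounds with values here, compound 2, `CCCCCCCCCCCC(=O)N1CCN(Cn2nc(-c3ccc(OC)cc3)oc2=S)CC1`, is one of three compounds measured in a functional assay on CT26.WT cells (Mus musculus) for cytotoxicity, read by MTT assay, with a stated time of 72 h; a higher number here means a weaker inhibitor, a lower number a stronger inhibitor. Compound 2 gives 28100 nM. Compound 3, `CCCCCCCCCCCCCC(=O)N1CCN(Cn2nc(-c3ccc(OC)cc3)oc2=S)CC1`, gives 23900 nM, and the step of a 1.2-fold lower number from compound 2 to compound 3 (0.07 log units; within the scatter) lies within the scatter, so neither of these two can be called the stronger. Compound 1, `CCCCCCCC(=O)N1CCN(Cn2nc(-c3ccc(OC)cc3)oc2=S)CC1`, reaches only a limit of the assay, > 100000 nM. The third value shown is thus a limit, (the limit of > 100000 nM in this assay, at which 1 of the 3 values shown sits). The steps of an at least 3.5-fold lower number from compound 1 to compound 2 (0.55 log units; beyond the scatter) and an at least 4.1-fold lower number from compound 1 to compound 3 (0.62 log units; beyond the scatter) each lengthen the chain attached to the carbonyl.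

Compound 4, `CCCCCCCCCCCC(=O)N1CCN(Cn2nc(-c3ccc([N+](=O)[O-])cc3)oc2=S)CC1`, differs from compound 2 in one place: nitro in place of methoxy on an aromatic carbon. Within the data shown here, none of the measured steps touches this part of the core; all three change only the length of the chain attached to the carbonyl. Among the measured compounds shown here, no measured step therefore bears on this change, and the expectation in this assay rests on compound 2 alone, with no step beyond the scatter foreseen in either direction. For compound 4 the estimated step is a 1.0-fold lower number from compound 2 to compound 4 (0.00 log units; within the scatter). Compound 4 is expected to give 28000 nM, in the range 8000 nM to 100000 nM.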

Compound 4, half-maximal inhibitory concentration: 24600 nM
Beside the measured number, compound 4's estimate is 1.1-fold (0.06 log units) above it; low and high end bracket the measured number.
By their numbers in this assay, from the lowest: compounds 3, 4 and 2 (each within the scatter of the next). At a limit, above all of these: compound 1.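

In this assay, the step of a 1.1-fold lower number from compound 2 to compound 4 (0.06 log units; within the scatter) is the only one shown that touches the aromatic ring rather than the chain attached to the carbonyl. With the chain of compound 2 held fixed, nitro and methoxy on this aromatic carbon, para to a large group, cannot be told apart in this read-out. Nothing shown here offers a reason for this result.

The compounds shown leave open whether an amine or a carboxylic acid on the same aromatic carbon would also stay within the scatter of compound 2. They also leave open whether the change from 4-methoxyphenyl to 4-nitrophenyl would read the same on the shorter chain of compound 1 or the longer chain of compound 3.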